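Kallikrein-7 inhibitor series: aryl substituent on the anilide

A few compounds are considered here, and "the series" means these few. Any claim that something is new, unique, unknown or untested is made for them only; others in the source may bear on it.

Measured in an assay on isolated protein for inhibition of kallikrein-7 (Homo sapiens), read by fluorescence, with stated times of 10 min and 30 min; a higher number here means a weaker inhibitor, a lower number a stronger inhibitor:
compound 1 `CNC(=O)c1cccc(NC(=O)CN2C/C(=N/N(C)C)NC[C@@H](Cc3cc(Cl)ccc3OC)C2=O)c1` gives 940 nM;
compound 2 `COc1ccc(Cl)cc1C[C@@H]1CN/C(=N\N(C)C)CN(CC(=O)Nc2cccc(S(=O)(=O)C(F)(F)F)c2)C1=O` gives 3900 nM.

Compound 2 has the higher of the two numbers; the step of a 4.1-fold higher number from compound 1 to compound 2 (0.62 log units; beyond the scatter) separates it from compound 1. Compound 3 `COc1ccc(Cl)cc1C[C@@H]1CN/C(=N\N(C)C)CN(CC(=O)Nc2cccc(-c3ccsc3)c2)C1=O` is not yet measured. It differs from compound 2 by thiophen-3-yl in place of (trifluoromethyl)sulfonyl on an aromatic carbon. Within the data shown here, no measured step replaces a group at this position with an aromatic ring, so the only step available, a 4.1-fold higher number from compound 1 to compound 2 (0.62 log units; beyond the scatter), bears on it indirectly: it shows that this position tolerates change of the group with a modest shift. Compound 3 is therefore expected to return toward the number of compound 1, with a step of a 2.2-fold lower number from compound 2 to compound 3 (0.34 log units; beyond the scatter) and an estimate of 1800 nM, range 500 nM to 6500 nM.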

Compound 3, half-maximal inhibitory concentration: 1500 nM
Compound 3: the middle estimate sits 1.2-fold (0.08 log units) above what was measured, and the stated range covers the measured number.
By their numbers in this assay, from the lowest: compounds 1 and 3 (each within the scatter of the next); then compound 2.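

In this assay thiophen-3-yl in place of (trifluoromethyl)sulfonyl gives a 2.6-fold lower number from compound 2 to compound 3 (0.41 log units; beyond the scatter) and thiophen-3-yl in place of methylcarbamoyl gives a 1.6-fold higher number from compound 1 to compound 3 (0.20 log units; within the scatter) so this position accepts an aromatic ring. Methylcarbamoyl and thiophen-3-yl cannot be separated here, and among these three groups only (trifluoromethyl)sulfonyl stands apart from both. Nothing available explains either step.

From the compounds shown here alone, whether a phenyl ring, an amine or a carboxylic acid on the same aromatic carbon would stand apart from compound 1 and compound 3 remains open.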